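The compounds below may be only part of what the source reports. "The series", "measured", "known", "first", "only" and "open" are said of these compounds alone.

Working notes on the series, read in an ADME assay on Vero cells (Chlorocebus sabaeus) for cytotoxicity, read by MTT assay, with a stated time of 96 h; a higher number here means that more compound is tolerated, a lower number that less compound is tolerated. Compound 1 `COc1ccc(-c2nc3cc(C(C)O)ccc3[nH]2)cc1` gives > 100000 nM, which is a limit and not a number. Compound 2 `COc1ccc(-c2nc3cc(C(C)O)ccc3[nH]2)c(OC)c1` gives > 100000 nM, also a limit. Compound 3 `COc1ccc(-c2nc3cc(C(C)O)ccc3[nH]2)c(OC)c1OC` gives >= 100000 nM, again a limit. The readings therefore sit at two limits: the limit of > 100000 nM in this assay, at which 2 of the 3 values shown sit, and (the limit of >= 100000 nM in this assay, at which 1 of the 3 values shown sits). Compound 2 has no numerical position, only a limit.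

The change to compound 4 `COc1ccc(-c2nc3cc(/C(C)=N/NC(N)=O)ccc3[nH]2)c(OC)c1` is a group of 7 heavy atoms (3 carbon, 3 nitrogen, 1 oxygen; no ring) in place of a group of 3 heavy atoms (2 carbon, 1 oxygen; no ring), on an aromatic carbon. The 1-hydroxyethyl group leaves, and a group with no common name enters on the same aromatic carbon.

Two measured steps are nearest: a step that the two limits leave unreadable from compound 1 to compound 2, and a step that the two limits leave unreadable from compound 2 to compound 3. Among the compounds with values here, both are methoxy in place of hydrogen on an aromatic carbon, so neither is the same change as the one made in compound 4, and neither has a readable size. The series therefore offers no measured size for this replacement, and the only anchor is the limit of compound 2. The expected at least 1.4-fold lower number from compound 2 to compound 4 (0.15 log units; that floor lies within the scatter) is not beyond the usual scatter, and any drift is expected towards less compound tolerated. For compound 4 the estimated value is 70000 nM, with an expected range of 15000 nM to 150000 nM.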

Compound 4, half-maximal cytotoxic concentration: 80000 nM
Estimate against measurement, compound 4: 1.1-fold (0.06 log units) below, within the range that was stated.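

In this assay compound 4 gives 80000 nM as the only reading among the compounds shown that is a number and not a limit, so this aromatic carbon, where the 1-hydroxyethyl group gives way to a group with no common name, now carries a measured value. On these data alone, the two methoxy steps among compound 1, compound 2 and compound 3 cannot be read, whereas this replacement is read as an at least 1.2-fold lower number from compound 2 to compound 4 (0.09 log units; that floor lies within the scatter) and so gives a floor, while its full size stays unknown. Compound 2 gives > 100000 nM as a limit and not a number, and the step stays a floor because of that limit: the limit of > 100000 nM in this assay, at which 2 of the 4 values shown sit.

As far as these compounds go, what a primary amine or a carboxylic acid on the same aromatic carbon would give remains open, as does the reading for a longer chain there. Also open, from the compounds shown here alone, is whether the reading of compound 4 would hold with the methoxy pattern of compound 1 or compound 3 on the shared core.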